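Methoxy Added to the Hydroxy-Bearing Ring of Compound 2

The source may hold more compounds than are shown below. What is called first, only, known or untested is meant among the compounds shown, and "the series" means these compounds.

Among the compounds with values here, compound 2 `Oc1ccc(-c2nc3cc(C(F)(F)F)ccc3[nH]2)cc1` gives 51.2% in a functional assay on aorta (Rattus norvegicus, strain Wistar) for inhibition, with a stated time of 60 min (a lower number here means a smaller maximal response, a higher number a larger maximal response), and, of the two numbers measured so far, stands at the same level as its only neighbour. Within the data shown here, compound 1 `CCCOc1ccc(-c2nc3cc(C(F)(F)F)ccc3[nH]2)cc1` gives 51% in this assay, and the single measured step, a number 0.2 percentage points higher from compound 1 to compound 2 (within the scatter), lies within the scatter, so the two compounds cannot be separated by this readout. Compound 3 `COc1cc(-c2nc3cc(C(F)(F)F)ccc3[nH]2)ccc1O` has not been measured; it differs from compound 2 by methoxy in place of hydrogen on an aromatic carbon. Among the measured compounds shown here, no measured step bears directly on this change: the step from compound 1 to compound 2 concerns the group carried on the oxygen, not an added substituent on the ring, and that step itself is flat. The series therefore gives no basis for a move in either direction, and the expected step of a number 0.2 percentage points lower from compound 2 to compound 3 (within the scatter) is taken to stay within the scatter. The estimate for compound 3 in this assay is 51%, with a range from 36% to 66%.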

Compound 3, largest response reached (Emax), in percent of the reference or control that the assay uses: 99.6%
The estimate for compound 3 lay 48.6 percentage points below the measured number, and the stated range ends below it.
By their numbers in this assay, from the lowest: compounds 1 and 2 (each within the scatter of the next); then compound 3.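

In this assay, within the data shown here, this ring carbon, ortho to a hydroxy group and meta to a large group, proves sensitive: methoxy in place of hydrogen there gives a number 48.4 percentage points higher from compound 2 to compound 3 (beyond the scatter) and so sets the first step beyond the scatter. The earlier pair covered only the group on the oxygen, where hydrogen in place of propyl gave a number 0.2 percentage points higher from compound 1 to compound 2 (within the scatter) and left the two compounds inseparable, so that flat step says nothing about the ring carbon. Nothing available on these compounds accounts for the rise, which stands as an observation on a single pair.

The compounds shown do not tell whether the rise belongs to methoxy itself or would also follow from another group on the same carbon, such as ethoxy, a fluorine atom or an amine. They also leave open whether the rise needs the free hydroxy group, since a propyl group on that oxygen alongside the methoxy would be a separate case, and one that the pairs shown here cannot predict.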